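The compounds below may be only part of what the source reports. "The series", "measured", "known", "first", "only" and "open" are said of these compounds alone.

Compound 1 `Cc1cccc(N2CCN(CCCNc3nc(NCc4ccco4)c4ccccc4n3)CC2)c1C` gives 770 nM in a functional assay on HCT-116 cells (Homo sapiens) for cytotoxicity, read by MTT assay, with a stated time of 2 days (on this read-out lower numbers stand for stronger inhibition and higher numbers for weaker inhibition), the lowest of the three numbers in hand, although neither neighbour is far away. Compound 3 `Cc1cccc(N2CCN(CCCNc3nc(NCc4ccco4)c4cc(F)ccc4n3)CC2)c1C`, which carries a fluoro in place of a hydrogen on an aromatic carbon of the shared core, gives 1140 nM in this assay, and the step of a 1.5-fold higher number from compound 1 to compound 3 (0.17 log units; within the scatter) lies within the scatter. Compound 2 `CCCCNc1nc(NCc2ccco2)c2cccc(F)c2n1` differs from compound 1 in more than one place; in this assay compound 2 gives 1330 nM, and the two values lie within the scatter of each other, so nothing can be said about their order.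

Compound 4 `Clc1cccc(N2CCN(CCCNc3nc(NCc4ccco4)c4ccccc4n3)CC2)c1Cl` has not yet been measured. It differs from compound 1 by 2,3-dichlorophenyl in place of 2,3-dimethylphenyl on an amine nitrogen in a ring. Among the measured compounds shown here, no measured step bears directly on this exchange: the only single-point step in hand, a 1.5-fold higher number from compound 1 to compound 3 (0.17 log units; within the scatter), concerns a different part of the molecule and stayed within the scatter. With nothing in the data to point either way, the expected step is a 1.0-fold higher number from compound 1 to compound 4 (0.02 log units; within the scatter), that is, no change beyond the scatter. The value of compound 4 in this assay is therefore estimated at 800 nM, with a range from 350 nM to 1800 nM.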

Compound 4, half-maximal inhibitory concentration: 3360 nM
Estimate against measurement, compound 4: 4.2-fold (0.62 log units) below, outside the stated range (above it).
By their numbers in this assay, from the lowest: compounds 1, 3 and 2 (each within the scatter of the next); then compound 4.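

In this assay, among the compounds shown here, the exchange of 2,3-dimethylphenyl for 2,3-dichlorophenyl on an amine nitrogen in a ring gives a 4.4-fold higher number from compound 1 to compound 4 (0.64 log units; beyond the scatter) and so provides the first single-place change in hand to pass beyond the scatter, whereas the fluoro exchange on the shared core, a 1.5-fold higher number from compound 1 to compound 3 (0.17 log units; within the scatter) and no more, did not. The number at this position therefore responds to the change of group, even though the two groups match in heavy-atom count, in their single six-membered aromatic ring of carbon only, and in their hydrogen-bond donor and acceptor counts, and carry no net charge. Nothing measured here explains the size or direction of this step.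

The compounds shown leave open whether both chlorines are needed for the step or a single chloro group would give it, and where an unsubstituted phenyl, a 2,3-difluorophenyl or a 2,3-dimethoxyphenyl would fall on the same scale. They also leave open whether the exchange would give a step of similar size on the fluoro-bearing core of compound 3 or on any other core.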